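Chloro Added to the Benzyl Group of Compound 3

This account rests on a few compounds, and the source may have more. Where it says the series, first, only, none or still open, it means among the compounds named here.

Of the compounds shown here, three have been measured in an assay for inhibition of Amine oxidase [flavin-containing] A (Rattus norvegicus); a higher number here means a weaker inhibitor, a lower number a stronger inhibitor. Compound 1 `N#CCCn1nc(-c2ccc(OCc3cccc(Cl)c3)cc2)oc1=O` gives 7400 nM. Compound 2 `N#CCCn1nc(-c2ccc(OCc3cccc(Cl)c3)cc2)oc1=S` gives 11000 nM in this assay. Compound 3 `N#CCCN1N=C(c2ccc(OCc3ccccc3)cc2)OCC1=O` gives 160000 nM in this assay, the highest of the three numbers; the gaps to compound 2 and to compound 1 both lie beyond the scatter. Going by the values given here, compound 1 and compound 2 differ from compound 3 in more than one place, so no single step between them is counted.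

Compound 4 `N#CCCN1N=C(c2ccc(OCc3ccc(Cl)cc3)cc2)OCC1=O` has not been measured in this assay. It differs from compound 3 by chloro in place of hydrogen on an aromatic carbon: the benzyl group becomes a 4-chlorobenzyl group, the chlorine sitting on an aromatic carbon para to a large group. Among the compounds with values here, no measured pair shows this exact step. The author expects the number for compound 4 to move somewhat lower than that of compound 3, since the two compounds carrying a chlorine on the benzyl ring, compound 1 with 7400 nM and compound 2 with 11000 nM, sit well below compound 3, though their core also differs. The step from compound 3 to compound 4 is expected as a 2.7-fold lower number from compound 3 to compound 4 (0.43 log units; beyond the scatter). Compound 4 is therefore estimated at 60000 nM, in a range from 15000 nM to 250000 nM.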

Compound 4, half-maximal inhibitory concentration: 3400 nM
Estimate against measurement, compound 4: 18-fold (1.25 log units) above; the measured number lies below the stated range.
By their numbers in this assay, from the lowest: compound 4; then compounds 1 and 2 (each within the scatter of the next); then compound 3.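

In this assay the single chlorine gives a 47-fold lower number from compound 3 to compound 4 (1.67 log units; beyond the scatter) on the shared core, so a change of one heavy atom at this place on the benzyl group is enough to move the number far beyond the scatter. Going by these compounds alone, compound 1 and compound 2 also carry a chlorine on the benzyl group, but each differs from compound 3 in more than one place, so this pair is the first to isolate the chloro group. No measurement shown here explains the size of this step.

The compounds shown leave open whether the step belongs to chlorine in particular or would also appear with fluoro, methyl or methoxy at the same place. They also leave open how much of it would remain if the chlorine stood elsewhere on the ring of this core.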